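Swapping the piperidine ring for a methylpiperazine

The compounds below may be only part of what the source reports. "The series", "measured", "known", "first", "only" and "open" are said of these compounds alone.

Compound 1 `Clc1ccc(-c2nc(N3CCCCC3)c3nc[nH]c3n2)cc1` was tested in an assay on cells for displacement of a labelled ligand from adenosine receptor A1 (Homo sapiens), read by scintillation counting and radioligand binding, with a stated time of 60 min (a higher number here means a weaker inhibitor, a lower number a stronger inhibitor), where compound 1 gives 126 nM. Of the two measured compounds it has the highest number, and so the weaker binding. Among the measured compounds shown here, the only companion is compound 2 `Oc1cccc(-c2nc(N3CCCCC3)c3nc[nH]c3n2)c1`, which in this assay gives 10 nM; the step of a 13-fold lower number from compound 1 to compound 2 (1.10 log units; beyond the scatter) comes from exchanging the aryl group on the shared core.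

Compound 3 `CN1CCN(c2nc(-c3ccc(Cl)cc3)nc3[nH]cnc23)CC1` keeps the 4-chlorophenyl group of compound 1 and changes a different part: 4-methylpiperazin-1-yl in place of piperidin-1-yl on an aromatic carbon. For the measured compounds named here, no measured step touches this position, since the one step seen so far, between compound 1 and compound 2, alters only the aryl group and therefore says nothing directly about the ring that carries the amine. With no guidance from the data on this change, the expectation for compound 3 rests mainly on compound 1 itself, with a wide range allowed. Compound 3 is expected to give about 300 nM, somewhere between 80 nM and 1200 nM, which would mean an estimated step of a 2.4-fold higher number from compound 1 to compound 3 (0.38 log units; beyond the scatter).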

Compound 3, inhibition constant: 398 nM
Compound 3: middle estimate off by 1.3-fold (0.12 log units), on the low side; measured number inside the range.
By their numbers in this assay, from the lowest: compound 2; then compound 1; then compound 3.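

In this assay, the amine ring on the shared core proves able to shift the number too, not only the aryl group: the exchange of piperidin-1-yl for 4-methylpiperazin-1-yl gives a 3.2-fold higher number from compound 1 to compound 3 (0.50 log units; beyond the scatter), a modest step, and smaller in size than the aryl exchange with a 13-fold lower number from compound 1 to compound 2 (1.10 log units; beyond the scatter). Among the compounds shown here, this single exchange brings in a second ring nitrogen and a methyl group together, so the step cannot be divided between those two parts, and it shows only that this particular ring does less well than piperidin-1-yl when the 4-chlorophenyl group is present. Nothing available explains why the number rises at this position.

A piperazine ring without the methyl group, or a morpholine ring, could show whether the added ring nitrogen or the methyl group accounts for the step. As far as these compounds go, it also remains open whether the same exchange would cost as much alongside the 3-hydroxyphenyl group of compound 2, which gives 10 nM with piperidin-1-yl in place.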